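The source may report more compounds than this note shows. Statements on the series, on what has been measured and on what is new or still open speak of the compounds shown alone.

Measured in an assay on cells for displacement of a labelled ligand from adenosine receptor A3 (Mus musculus), read by scintillation counting and radioligand binding, with stated times of 10 min and 90 min, tested at 10 uM; a higher number here means more inhibition at the concentration tested (going by the name of the read-out), a lower number less inhibition:

- compound 1 `CNc1nc(C#Cc2ccc(Cl)s2)nc2c1ncn2[C@H]1[C@H](O)[C@H](O)[C@]2(C(=O)OC(C)C)C[C@H]12` gives 30%
- compound 2 `CCCCOC(=O)[C@@]12C[C@@H]1[C@@H](n1cnc3c(NC)nc(C#Cc4ccc(Cl)s4)nc31)[C@H](O)[C@@H]2O` gives 54%
- compound 3 `CNc1nc(C#Cc2ccc(Cl)s2)nc2c1ncn2[C@H]1[C@H](O)[C@H](O)[C@]2(C(=O)OCCC(C)C)C[C@H]12` gives 32%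

Compound 3 stands second highest of the three numbers; its nearest neighbour is compound 1, within the scatter, and its furthest is compound 2, beyond the scatter. Among the measured steps, butyl for isopropyl gave a number 24 percentage points higher from compound 1 to compound 2 (beyond the scatter), isopentyl for isopropyl gave a number 2 percentage points higher from compound 1 to compound 3 (within the scatter), and adding a methyl on the chain gave a number 22 percentage points lower from compound 2 to compound 3 (beyond the scatter). The ester substituent is thus the only variable in this set, and its changes have stayed modest.

Compound 4 `CNc1nc(C#Cc2ccc(Cl)s2)nc2c1ncn2[C@H]1[C@H](O)[C@H](O)[C@]2(C(=O)OCCC3CCCCC3)C[C@H]12` is not yet measured. It differs from compound 3 by cyclohexyl in place of isopropyl on a saturated chain carbon, two bonds along the chain from an oxygen next to a carbonyl group. Going by the values given here, no measured step tests a ring at this position, so the bearing of the measured steps is indirect: enlarging or branching the chain has moved this assay little or somewhat downward. A small step is therefore expected, likely none beyond the scatter, with a slight lean downward, as a number 4 percentage points lower from compound 3 to compound 4 (within the scatter). Compound 4 is estimated at 28%, within 8% to 50%.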

Compound 4, a percentage reported as inhibition, at one concentration (the size of the read-out at that concentration, not a potency): 5%
Estimate against measurement, compound 4: 23 percentage points above, and the stated range ends above it.
By their numbers in this assay, from the lowest: compound 4; then compounds 1 and 3 (each within the scatter of the next); then compound 2.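

In this assay, a ring at the end of the ester chain lowers the number where branching alone did not separate compound 1 from compound 3: cyclohexyl in place of isopropyl gives a number 27 percentage points lower from compound 3 to compound 4 (beyond the scatter). The 2-cyclohexylethyl ester also falls against the two simpler esters, with a number 49 percentage points lower from compound 2 to compound 4 (beyond the scatter) and a number 25 percentage points lower from compound 1 to compound 4 (beyond the scatter), which leaves compound 4 lowest of the four. No data are available that account for this drop.

As far as these compounds go, whether the ring or the overall chain size drives the fall remains open; a straight hexyl or octyl ester would help separate the two. A cyclohexylmethyl or 2-phenylethyl ester would show how the result depends on ring distance and ring type.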